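From pyrimidin-2-yl to 1-methyl-1H-imidazol-4-yl

The source may hold more compounds than are shown below. What is called first, only, known or untested is meant among the compounds shown, and "the series" means these compounds.

Compound 1 `CN(C)C(=O)c1nc([C@@H](O)[C@H](O)[C@H](O)CO)c[nH]1`: 11.3 mL/min/kg
Compound 2 `Cc1nc(-c2nc([C@@H](O)[C@H](O)[C@H](O)CO)c[nH]2)cs1`: 19.4 mL/min/kg
Compound 3 `OC[C@@H](O)[C@@H](O)[C@H](O)c1c[nH]c(-c2ncccn2)n1`: 15.2 mL/min/kg

All three values come from an in vivo ADME assay on the whole organism (strain 129/SvEvBrd x C57BL/6) for pharmacokinetics, with Mus musculus as the target, at a dose of 1 mg/kg by the intravenous route; a higher number here means faster removal of the compound, a lower number slower removal. Compound 3 stands within the scatter of both other compounds, as shown by a 1.3-fold higher number from compound 1 to compound 3 (0.13 log units; within the scatter) and a 1.3-fold lower number from compound 2 to compound 3 (0.11 log units; within the scatter). The remaining member of the series is compound 4 `Cn1cnc(-c2nc([C@@H](O)[C@H](O)[C@H](O)CO)c[nH]2)c1`, which has 1-methyl-1H-imidazol-4-yl in place of pyrimidin-2-yl on an aromatic carbon.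

Among the measured compounds shown here, all the measured steps bear on this change, since each swaps the group on that same aromatic carbon. The third of them, a 1.7-fold higher number from compound 1 to compound 2 (0.23 log units; within the scatter), also stays within the scatter. For the measured compounds named here, no measured compound carries 1-methyl-1H-imidazol-4-yl, so the estimate is an extrapolation from other groups. With three different groups giving no step beyond the scatter, no step beyond the scatter is expected here, and no direction can be called.

The expected change is a 1.0-fold lower number from compound 3 to compound 4 (0.01 log units; within the scatter). Compound 4 is estimated at 15 mL/min/kg. The expected range for compound 4 runs from 9 mL/min/kg to 26 mL/min/kg.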

Compound 4, clearance: 9.1 mL/min/kg
For compound 4 the middle estimate is 1.6-fold (0.22 log units) above the measured one; the range from low to high includes it.
By their numbers in this assay, from the lowest: compounds 4, 1, 3 and 2 (each within the scatter of the next, the first and the last beyond it).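

In this assay, swapping groups on this aromatic carbon, between two ring nitrogen atoms, now gives a step beyond the scatter: a 2.1-fold lower number from compound 2 to compound 4 (0.33 log units; beyond the scatter) is modest in size and comes with 1-methyl-1H-imidazol-4-yl in place of 2-methyl-1,3-thiazol-4-yl. The other two steps, a 1.7-fold lower number from compound 3 to compound 4 (0.22 log units; within the scatter) and a 1.2-fold lower number from compound 1 to compound 4 (0.09 log units; within the scatter), stay within the scatter, so 1-methyl-1H-imidazol-4-yl cannot be ordered against pyrimidin-2-yl or dimethylcarbamoyl. Across the four groups, only compound 2 and compound 4 are separated, and the spread at this position remains narrow.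

From the compounds shown here alone, whether an amine, a carboxylic acid or a longer chain on this carbon would move the number further remains open. No measurement shown accounts for the one step beyond the scatter.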